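Swapping fluoro for methyl beside a ring nitrogen

The compounds below may be only part of what the source reports. "The series", "measured", "known", "first", "only" and "open" are said of these compounds alone.

Three compounds share one core, a chain ending in a carboxylic acid on a benzene joined through a triple bond to a six-membered aromatic ring that carries one or two nitrogens. Compound 1 `Cc1cc(C#Cc2ccc(CCC(=O)O)cc2)nc(Cl)n1`, compound 2 `O=C(O)CCc1ccc(C#Cc2ccnc(F)c2)cc1` and compound 3 `O=C(O)CCc1ccc(C#Cc2ccc(Cl)nc2)cc1` were all tested in an in vitro functional assay on 1321-N1 cells for agonist activity at Free fatty acid receptor 1 (Homo sapiens), read by fluorescence, spectrophotometry and calcium flux; on this read-out higher numbers stand for larger maximal responses and lower numbers for smaller maximal responses. Compound 1 gives 110%, compound 2 gives 98% and compound 3 gives 98%. Compound 2 thus stands level with compound 3 at the digits shown, the two together being the lowest of the three numbers, while compound 1 lies a dozen percentage points higher, a gap beyond the usual scatter.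

Compound 4 `Cc1cc(C#Cc2ccc(CCC(=O)O)cc2)ccn1` has not yet been measured. It differs from compound 2 in one place: methyl in place of fluoro on an aromatic carbon. The change sits on an aromatic carbon of a six-membered aromatic ring with one nitrogen, next to the ring nitrogen and meta to a large group. Compound 1 also carries a methyl next to a ring nitrogen and gives 110%, so a large response seems likely. The step of a number 5 percentage points higher from compound 2 to compound 4 (within the scatter) is expected to be small, within the scatter. Compound 4 is estimated to reach 103%, in a range from 90% to 116%.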

Compound 4, largest response reached (reported as efficacy), in percent of the reference or control that the assay uses: 102%
For compound 4 the middle estimate is 1 percentage points above the measured one; the range from low to high includes it.
By their numbers in this assay, from the lowest: compounds 2, 3, 4 and 1 (each within the scatter of the next, the first and the last beyond it).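

In this assay, putting methyl in place of fluoro on an aromatic carbon gives a number 4 percentage points higher from compound 2 to compound 4 (within the scatter). Among the compounds shown here, this is the first comparison here between two compounds that differ in one place, so it isolates this change from the other differences among the earlier compounds, and at this position, next to the ring nitrogen, the exchange leaves the maximal response unchanged within the usual scatter of the measurement. No measured information is available on why fluoro and methyl give such similar results here.

The compounds shown leave open whether this position would accept groups that differ more from these two, such as a methoxy group, a trifluoromethyl group, an amine or a longer chain like propyl, or whether the response would then fall. They also leave open whether fluoro and methyl match in how much compound is needed to produce the response, since the largest response reached says nothing about the concentration at which it is reached.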